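From Compound 1 to Compound 3: the Amide Changes

The compounds below may be only part of what the source reports. "The series", "measured", "known", "first", "only" and "open" are said of these compounds alone.

For the measured compounds named here, compound 1 `COc1cccc(C(=O)Nc2cc(-c3ccccc3)nn2-c2ccccc2)c1` is the only compound in this set with a numeric reading in an assay on HEK293 cells for displacement of a labelled ligand from metabotropic glutamate receptor 5 (Rattus norvegicus) (a higher number here means a weaker inhibitor, a lower number a stronger inhibitor), where compound 1 gives 1290 nM. Compound 2 `O=C(Nc1cc(-c2ccccc2Cl)nn1-c1ccccc1)c1ccccc1` stands apart: in this assay compound 2 returns > 10000 nM, which is a limit of the assay rather than a number, as recorded in the limit of > 10000 nM in this assay, at which 1 of the 2 values shown sits. Going by the values given here, with one number and one limit, compound 1 is the sole measured reference point, and no step between measured compounds can be drawn from these two.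

Compound 3 `O=C(Nc1cc(-c2ccccc2)nn1-c1ccccc1)C1CCCCC1` has not yet been tested in this assay. It differs from compound 1 in one place: cyclohexyl in place of 3-methoxyphenyl on a carbonyl carbon. Among the compounds with values here, no measured pair shows what such a change does here, so the expectation rests on compound 1 alone. The step of a 2.7-fold higher number from compound 1 to compound 3 (0.43 log units; beyond the scatter) is expected to lie beyond the usual scatter, in the direction of weaker inhibition. For compound 3 the estimated inhibition constant in this assay is 3500 nM, with an expected range from 900 nM to 13000 nM.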

Compound 3, inhibition constant: 10100 nM
Beside the measured number, compound 3's estimate is 2.9-fold (0.46 log units) below it; measured number inside the range.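

The first measured step at this position in this assay is a 7.8-fold higher number from compound 1 to compound 3 (0.89 log units; beyond the scatter), for cyclohexyl in place of 3-methoxyphenyl on a carbonyl carbon, so the group held there is not indifferent to the reading, and the aromatic group is the better of the two shown. The change alters several things at once: a six-membered aromatic ring of carbon only gives way to a six-membered non-aromatic ring of carbon only, the oxygen leaves, and the hydrogen-bond acceptor count of the group falls, and this single step cannot separate these differences from one another. Compound 3 still returns a number, whereas compound 2 stays recorded as a limit of the assay and gives no step to compound 1 or compound 3: the limit of > 10000 nM in this assay, at which 1 of the 3 values shown sits.

On these data alone, what remains open is whether the loss follows from the missing methoxy group or from the missing aromatic ring, a question that the two groups compared here cannot settle. How a pyridyl ring or a straight butyl chain on the same carbonyl carbon would read also stays unknown from the compounds shown.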